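Swapping the Carboxypiperidine for a Hydroxypyrrolidine

The source may hold more compounds than are shown below. What is called first, only, known or untested is meant among the compounds shown, and "the series" means these compounds.

Compound 1 `COc1ccc(/C=C\c2cc(OC)c(OC)c(OC)c2)cc1OCc1ccc(CN2CCCC[C@H]2C(=O)O)cc1` was tested in a functional assay on MC-38 cells (Mus musculus) for antiproliferative activity, read by CCK-8 assay, with a stated time of 48 h (on this read-out lower numbers stand for stronger inhibition and higher numbers for weaker inhibition), and gives only a limit, > 10000 nM. Compound 2 `COc1ccc(/C=C\c2cc(OC)c(OC)c(OC)c2)cc1OCc1ccc(CN2CCCCC2C(=O)O)cc1` gives 5400 nM, and compound 3 `COc1ccc(/C=C\c2cc(OC)c(OC)c(OC)c2)cc1OCc1ccc(CN2CC[C@H](O)C2)cc1` gives 7200 nM. One measured step, an at least 1.8-fold lower number from compound 1 to compound 2 (0.26 log units; that floor lies within the scatter), rests on (the fact that one of compounds 1 and 2 is drawn with a defined configuration and the other without, at the place where they differ). Compound 4 `COc1ccc(/C=C\c2cc(OC)c(OC)c(OC)c2)cc1OCc1ccc(CN2CC[C@@H](O)C2)cc1` differs from compound 1 by 3-hydroxypyrrolidin-1-yl in place of 2-carboxypiperidin-1-yl on a saturated chain carbon bound to an aromatic carbon. The same change is seen in an at least 1.3-fold lower number from compound 1 to compound 3 (0.14 log units; that floor lies within the scatter) and in a 1.3-fold higher number from compound 2 to compound 3 (0.12 log units; within the scatter), and neither of these reaches beyond the scatter. Compound 1 cannot set a step size because its value is the limit (the limit of > 10000 nM in this assay, at which 1 of the 3 values shown sits), so compound 3 serves as the nearest guide. The expected step is an at least 1.3-fold lower number from compound 1 to compound 4 (0.12 log units; that floor lies within the scatter). Compound 4 is therefore estimated at 7500 nM, with a range from 3000 nM to 20000 nM.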

Compound 4, half-maximal inhibitory concentration: 6900 nM
Estimate against measurement, compound 4: 1.1-fold (0.04 log units) above; low and high end bracket the measured number.
By their numbers in this assay, from the lowest: compounds 2, 4 and 3 (each within the scatter of the next). At a limit, above all of these: compound 1.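

With the step (a 1.0-fold lower number from compound 3 to compound 4 (0.02 log units; within the scatter)) in this assay, reversing the drawn configuration of the 3-hydroxypyrrolidin-1-yl group leaves the number within the scatter: (the fact that compounds 3 and 4 differ only in the configuration as drawn). Compound 4 also stays within the scatter of the carboxypiperidine drawn without a configuration (a 1.3-fold higher number from compound 2 to compound 4 (0.11 log units; within the scatter)). The remaining step (an at least 1.4-fold lower number from compound 1 to compound 4 (0.16 log units; that floor lies within the scatter)) is only a floor: (the limit of > 10000 nM in this assay, at which 1 of the 4 values shown sits). From the compounds shown here alone, how far compound 1 lies past its limit stays open. So does whether a dimethylamino group or a longer chain at this place would move the number beyond the scatter.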